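Sulfonamide heteroaryl swap on a diterpenoid lactone series

A few compounds are considered here, and "the series" means these few. Any claim that something is new, unique, unknown or untested is made for them only; others in the source may bear on it.

Measured so far:
Compound 1 `C=C1CC[C@@H]2[C@](C)(COC(C)=O)[C@H](OC(C)=O)CC[C@@]2(C)[C@H]1CC(Nc1ccc(S(=O)(=O)Nc2cc(C)on2)cc1)C1=CCOC1=O` gives 7610 nM in a functional assay on OVCAR-5 cells (Homo sapiens) for inhibition, read by sulforhodamine B assay, with a stated time of 48 h; on this read-out higher numbers stand for lower toxicity in this test and lower numbers for higher toxicity in this test.
Compound 2 `C=C1CC[C@@H]2[C@](C)(COC(C)=O)[C@H](OC(C)=O)CC[C@@]2(C)[C@H]1CC(Nc1ccc(S(=O)(=O)Nc2ncccn2)cc1)C1=CCOC1=O` gives 7470 nM in this assay.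

Compound 1 holds the highest of the two numbers in this assay, with compound 2 nearest at a 1.0-fold lower number from compound 1 to compound 2 (0.01 log units; within the scatter). Compound 3 `C=C1CC[C@@H]2[C@](C)(COC(C)=O)[C@H](OC(C)=O)CC[C@@]2(C)[C@H]1CC(Nc1ccc(S(=O)(=O)Nc2nccs2)cc1)C1=CCOC1=O` differs from compound 1 by 1,3-thiazol-2-yl in place of 5-methyl-1,2-oxazol-3-yl on a sulfonamide nitrogen. Among the measured compounds shown here, the only step that bears on this is the one from compound 1 to compound 2, another swap of the five-membered ring on the sulfonamide nitrogen, and it stayed within the scatter. The expected step is therefore a 1.0-fold lower number from compound 1 to compound 3 (0.01 log units; within the scatter), nothing beyond the scatter. The estimate for compound 3 in this assay is 7500 nM, ranging from 3800 nM to 15000 nM.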

Compound 3, concentration lethal to 50% of the cells: 46900 nM
Compound 3: middle estimate off by 6.3-fold (0.80 log units), on the low side; the whole stated range lies below it.
By their numbers in this assay, from the lowest: compounds 2 and 1 (each within the scatter of the next); then compound 3.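

Swapping the group on a sulfonamide nitrogen can move the read-out in this assay, which the step between compound 1 and compound 2 did not show: 1,3-thiazol-2-yl in place of 5-methyl-1,2-oxazol-3-yl gives a 6.2-fold higher number from compound 1 to compound 3 (0.79 log units; beyond the scatter), and in place of pyrimidin-2-yl it gives a 6.3-fold higher number from compound 2 to compound 3 (0.80 log units; beyond the scatter). Compound 3 is therefore the least toxic of the three in this test. Nothing available explains why this group stands apart.

Still open, going by these compounds, is whether a 1,3-oxazol-2-yl or a plain phenyl on that nitrogen would fall with compound 3 or with compound 1 and compound 2.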